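Replacing the thiophene acyl group on the shared core

The source may report more compounds than this note shows. Statements on the series, on what has been measured and on what is new or still open speak of the compounds shown alone.

Measured so far:
compound 1, `COc1cc(/C=C/C(=O)c2cccc(NC(=O)c3cccs3)c2)ccc1O`, 80%
compound 2, `COc1cc(/C=C/C(=O)c2cccc(N)c2)ccc1O`, 50%
compound 3, `COc1cc(/C=C/C(=O)c2cccc(NC(=O)C(C)C)c2)ccc1O`, 51%

The three measured compounds share one core and differ only in what sits on the aromatic amine nitrogen. In a functional assay on HUVEC cells (Homo sapiens) for inhibition, tested at 5 ug/mL (on this read-out higher numbers stand for a stronger effect at the one concentration tested and lower numbers for a weaker effect), compound 1 gives the highest of the three numbers; compound 3 and compound 2 lie well below it, each beyond the scatter. Two steps lead away from compound 1: a number 30 percentage points lower from compound 1 to compound 2 (beyond the scatter) when the acyl group is removed entirely, and a number 29 percentage points lower from compound 1 to compound 3 (beyond the scatter) when the thiophene ring is exchanged for a small alkyl group. Between compound 2 and compound 3 the numbers hardly move, a number 1 percentage points higher from compound 2 to compound 3 (within the scatter), so on these data the isopropyl amide does no better than the free amine.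

Compound 4, `COC(=O)C(=O)Nc1cccc(C(=O)/C=C/c2ccc(O)c(OC)c2)c1`, is still to be measured. It differs from compound 1 as follows: methoxycarbonyl in place of thiophen-2-yl on a carbonyl carbon. This is the same kind of change as the step from compound 1 to compound 3, where the thiophene ring gave way to another group on that carbonyl carbon, and that step was a modest loss. Neither measured step speaks for the thiophene ring being dispensable, so a loss of similar size is expected here, a number 25 percentage points lower from compound 1 to compound 4 (beyond the scatter), landing compound 4 near the level of compound 3. Compound 4 is therefore estimated at 55%, in the range 38% to 72%.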

Compound 4, a percentage reported as inhibition, at one concentration (the size of the read-out at that concentration, not a potency): 20%
Compound 4: the middle estimate sits 35 percentage points above what was measured, outside the stated range (below it).
By their numbers in this assay, from the lowest: compound 4; then compounds 2 and 3 (each within the scatter of the next); then compound 1.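

In this assay, for the compounds shown here, the group on the carbonyl carbon bonded to the amide-type nitrogen can do more than the earlier compounds showed, since methoxycarbonyl in place of thiophen-2-yl gives a number 60 percentage points lower from compound 1 to compound 4 (beyond the scatter). Acylation of the nitrogen had so far either raised the number or left it within the scatter, but (methoxycarbonyl)carbonyl in place of hydrogen gives a number 30 percentage points lower from compound 2 to compound 4 (beyond the scatter), so an acyl group can also leave the number beyond the scatter below that of the free amine; methoxycarbonyl in place of isopropyl likewise gives a number 31 percentage points lower from compound 3 to compound 4 (beyond the scatter), which shows that the two non-aromatic groups are not interchangeable at this place. No measurement of any property of these groups is at hand to account for these differences.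

The compounds shown leave open whether the low number goes with methoxycarbonyl as a whole or with its methoxy end, and what a carboxylic acid or a plain methyl group on that carbonyl carbon would give. As far as these compounds go, it also stays open whether a longer alkyl chain there would remain near isopropyl or move towards thiophen-2-yl.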